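Shortening the hydroxamate arm of compound 1

The source may hold more compounds than are shown below. What is called first, only, known or untested is meant among the compounds shown, and "the series" means these compounds.

Two compounds share a propargyl-bearing amine chain on an aromatic ether and a terminal hydroxamic acid. In an assay on isolated protein for inhibition of histone deacetylase 8 (Homo sapiens), read by fluorescence (on this read-out higher numbers stand for weaker inhibition and lower numbers for stronger inhibition), compound 1, `C#CCN(C)CCCOc1cc(NCc2ccc(/C=C/C(=O)NO)cc2)ccc1Cl`, gives 80 nM, while compound 2, `C#CCN(C)CCCOc1cc(NC(=O)CCCCCCC(=O)NO)c(Cl)cc1Cl`, gives 1780 nM. Compound 1 thus holds the lower of the two numbers, and compound 2 sits beyond the usual scatter above it.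

Compound 3, `C#CCN(C)CCCOc1cc(NCc2ccc(C(=O)NO)cc2)ccc1Cl`, differs from compound 1 in one place: hydroxycarbamoyl in place of 2-(hydroxycarbamoyl)ethenyl on an aromatic carbon. The two compounds otherwise match exactly. Among the compounds with values here, no measured pair traces this change, so its effect is not known from the data. The shift from compound 1 to compound 3 is expected to be modest, within or only slightly beyond the scatter, and if anything toward a higher number, estimated as a 1.9-fold higher number from compound 1 to compound 3 (0.27 log units; within the scatter). Compound 3 is therefore expected to give about 150 nM in this assay, with a range from 40 nM to 600 nM.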

Compound 3, half-maximal inhibitory concentration: 1170 nM
Beside the measured number, compound 3's estimate is 7.8-fold (0.89 log units) below it; the measured number lies above the stated range.
By their numbers in this assay, from the lowest: compound 1; then compounds 3 and 2 (each within the scatter of the next).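

Replacing 2-(hydroxycarbamoyl)ethenyl with hydroxycarbamoyl on this aromatic carbon, para to a large group, is far from a neutral change in this assay: it gives a 15-fold higher number from compound 1 to compound 3 (1.17 log units; beyond the scatter). The earlier compounds shown here offered no direct reading of this change; here the group goes from 6 heavy atoms to 4 and from 2 double bonds outside aromatic rings to 1, while hydrogen-bond donors and acceptors stay at 2 each and the rest of the structure is unchanged. No available evidence accounts for the size of this step.

The compounds shown leave open whether the double bond or the length of the arm matters more, which 2-(hydroxycarbamoyl)ethyl or a longer chain ending in hydroxycarbamoyl could help to separate. As far as these compounds go, whether a carboxylic acid at this place would retain any inhibition also remains open.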